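From Pyridin-3-yl to Pyridin-4-yl: An Expected Outcome

The source may report more compounds than this note shows. Statements on the series, on what has been measured and on what is new or still open speak of the compounds shown alone.

Going by the values given here, compound 2 `COc1cc(OC)c(C(=O)/C=C/c2cn(-c3ccccc3)nc2-c2cccnc2)c(OC)c1` gives 300 nM in a functional assay on HCT-116 cells (Homo sapiens) for inhibition, read by sulforhodamine B assay, with a stated time of 72 h (on this read-out higher numbers stand for weaker inhibition and lower numbers for stronger inhibition), the lowest of the two numbers measured so far; its nearest neighbour is compound 1 `COc1cc(OC)c(C(=O)/C=C/c2cn(-c3ccccc3)nc2-c2ccsc2)c(OC)c1`, which in this assay gives 5200 nM. Among the compounds with values here, the single measured step between them, a 17-fold lower number from compound 1 to compound 2 (1.24 log units; beyond the scatter), exchanges thiophen-3-yl for pyridin-3-yl on an aromatic carbon. Compound 3 `COc1cc(OC)c(C(=O)/C=C/c2cn(-c3ccccc3)nc2-c2ccncc2)c(OC)c1` differs from compound 2 by pyridin-4-yl in place of pyridin-3-yl on an aromatic carbon; the two have the same atoms, joined differently. Within the data shown here, the step from compound 1 to compound 2 shows only that swapping the whole ring for pyridin-3-yl lowered the number strongly; it says nothing about how the two pyridinyl isomers compare. Among the measured compounds shown here, with no step of that kind measured, a change within the scatter is expected, a 1.3-fold higher number from compound 2 to compound 3 (0.12 log units; within the scatter). Compound 3 is therefore estimated to give 400 nM in this assay, within a range from 150 nM to 1500 nM.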

Compound 3, half-maximal inhibitory concentration: 600 nM
Beside the measured number, compound 3's estimate is 1.5-fold (0.18 log units) below it, within the range that was stated.
By their numbers in this assay, from the lowest: compounds 2 and 3 (each within the scatter of the next); then compound 1.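

In this assay, this position, an aromatic carbon of a five-membered aromatic ring with 2 nitrogen, does not separate the two pyridinyl isomers: exchanging pyridin-3-yl for pyridin-4-yl gives a 2.0-fold higher number from compound 2 to compound 3 (0.30 log units; within the scatter), so compound 2 and compound 3 cannot be told apart here. The earlier advantage over thiophen-3-yl is therefore not confined to pyridin-3-yl, since pyridin-4-yl also brings an 8.7-fold lower number from compound 1 to compound 3 (0.94 log units; beyond the scatter), a step beyond the scatter. Nothing measured alongside these numbers accounts for the difference between the pyridinyl groups and thiophen-3-yl.

On these data alone, how a plain phenyl, a pyridin-2-yl or an amine such as piperidin-1-yl would compare at this position remains open. So does whether the two pyridinyl groups would stay this close on a core altered elsewhere.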